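Glycosylated chromones: isomeric side chain, same chain atoms

The source may hold more compounds than are shown below. What is called first, only, known or untested is meant among the compounds shown, and "the series" means these compounds.

Measured so far:
Compound 1 `C/C(=C/Cc1c(O)cc2oc(CO)cc(=O)c2c1O)CO[C@@H]1O[C@H](CO)[C@@H](O)[C@H](O)[C@H]1O`: 73.1%
Compound 2 `C/C(=C/Cc1c(O[C@@H]2O[C@H](CO)[C@@H](O)[C@H](O)[C@H]2O)cc2oc(CO)cc(=O)c2c1O)CO`: 68.9%

In a functional assay on 3T3-L1 cells (Mus musculus) for inhibition, read by ELISA, with a stated time of 8 days, tested at 300 uM (a lower number here means less inhibition, a higher number more inhibition at the concentration tested (going by the name of the read-out)), compound 2 gives 68.9%. Compound 1 gives 73.1% in this assay, and the two values lie within the usual scatter of each other, so no order between them can be read from these numbers.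

Compound 3 `C=C(C)C(O)Cc1c(O[C@@H]2O[C@H](CO)[C@@H](O)[C@H](O)[C@H]2O)cc2oc(CO)cc(=O)c2c1O` has not yet been measured. It differs from compound 2 only in the side chain on the shared core: 1-hydroxy-2-methylprop-2-en-1-yl in place of 2-(hydroxymethyl)prop-1-en-1-yl on a saturated chain carbon bound to an aromatic carbon. The chain keeps its atoms and is joined differently.

Going by the values given here, no step between two measured compounds is at hand to show what such a rearrangement of the chain does. The expectation is therefore a step of a number 2.9 percentage points lower from compound 2 to compound 3 (within the scatter) of no size beyond the scatter, in neither direction. For compound 3 the estimate in this assay is 66%, with a range from 48% to 84%.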

Compound 3, a percentage reported as inhibition, at one concentration (the size of the read-out at that concentration, not a potency): 82.2%
Compound 3: middle estimate off by 16.2 percentage points, on the low side; low and high end bracket the measured number.
By their numbers in this assay, from the lowest: compounds 2, 1 and 3 (each within the scatter of the next, the first and the last beyond it).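

In this assay, rearranging the same chain atoms from 2-(hydroxymethyl)prop-1-en-1-yl to 1-hydroxy-2-methylprop-2-en-1-yl gives a number 13.3 percentage points higher from compound 2 to compound 3 (beyond the scatter). Going by these compounds alone, the read-out at this position, on a saturated chain carbon bound to an aromatic carbon, therefore depends on how the chain is joined, and not only on which atoms it contains, although this single modest step is the only evidence for that. Nothing at hand accounts for the step.

As far as these compounds go, this one pair cannot separate the new site of the chain hydroxyl from the new site of the double bond, so it remains open which of the two carries the step. It also leaves open whether an amine in place of that hydroxyl, or a longer chain, would keep the read-out of compound 3.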